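The compounds below may be only part of what the source reports. "The series", "measured", "known", "first", "only" and "open" are said of these compounds alone.

In an ADME assay on MT4 cells (Homo sapiens) for cytotoxicity, read by MTT assay, with a stated time of 4 days (on this read-out lower numbers stand for higher toxicity in this test and higher numbers for lower toxicity in this test), three compounds that share one core have been measured. Compound 1 (`COc1ccccc1-c1oc2ccc(NC(C)=O)cc2c(=O)c1O`) gives 385000 nM and stands apart from the other two. Compound 2 (`COc1cccc(-c2oc3ccc(NC(C)=O)cc3c(=O)c2O)c1`) gives 33300 nM and compound 3 (`CC(=O)Nc1ccc2oc(-c3ccc(F)cc3)c(O)c(=O)c2c1`) gives 34100 nM in the same test. Compound 3 thus stands level with its nearest neighbour, with a 1.0-fold higher number from compound 2 to compound 3 (0.01 log units; within the scatter) as the step, and well under the highest number, with an 11-fold lower number from compound 1 to compound 3 (1.05 log units; beyond the scatter) and a 12-fold lower number from compound 1 to compound 2 (1.06 log units; beyond the scatter) as the two large steps. Compound 4 (`Nc1ccc2oc(-c3ccc(F)cc3)c(O)c(=O)c2c1`) keeps everything in compound 3 except for one change (hydrogen in place of acetyl on a nitrogen on an aromatic ring): hydrogen in place of acetyl on a nitrogen on an aromatic ring, or acetamido to amino. Every measured step exchanges only the substituted phenyl group, so none of them bears directly on this change, and their size cannot be carried over. Only a modest shift towards a lower number is therefore expected, possibly one that stays within the scatter, and the direction is uncertain. The expected change is a 1.7-fold lower number from compound 3 to compound 4 (0.23 log units; within the scatter) in this estimate. Compound 4 is estimated at 20000 nM (range 6000 nM to 60000 nM) in this assay once it is measured.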

Compound 4, half-maximal cytotoxic concentration: 92600 nM
Estimate against measurement, compound 4: 4.6-fold (0.67 log units) below; the whole stated range lies below it.
By their numbers in this assay, from the lowest: compounds 2 and 3 (each within the scatter of the next); then compound 4; then compound 1.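

Among the compounds shown here, the change from acetamido to amino is the first measured step away from the substituted phenyl group, and in this assay it gives a 2.7-fold higher number from compound 3 to compound 4 (0.43 log units; beyond the scatter). The number in this test therefore responds to the group on the nitrogen on an aromatic ring as well as to the phenyl group, with loss of the acetyl moving it towards lower toxicity in this test, though this modest step stands against the large 11-fold lower number from compound 1 to compound 3 (1.05 log units; beyond the scatter). Nothing in the data offers a reason for this shift.

On these data alone, the change is seen on the 4-fluorophenyl compounds alone, so it remains open whether it would run the same way with 2-methoxyphenyl or 3-methoxyphenyl in that place. Also open, as far as these compounds go, is how a longer acyl chain such as propanoyl, a single methyl or a methanesulfonyl group on that nitrogen would compare.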